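This account rests on a few compounds, and the source may have more. Where it says the series, first, only, none or still open, it means among the compounds named here.

Compound 1 `Cc1nc(SCC(=O)Nc2nc(-c3ccc(Cl)cc3)cs2)n(Nc2ccccc2)c1C` has been measured in a functional assay on DU-145 cells (Homo sapiens) for antiproliferative activity, read by sulforhodamine B assay, with a stated time of 48 h (on this read-out lower numbers stand for stronger inhibition of growth and higher numbers for weaker inhibition of growth), where compound 1 gives 5640 nM. Compound 2 `Cc1ccc(Nn2c(SCC(=O)Nc3nc(-c4ccccc4)cs3)nc(C)c2C)cc1` differs from compound 1 at two places; in this assay compound 2 gives 9750 nM. The two numbers lie within the scatter of each other, so no order between them is claimed. Compound 3 `COc1ccc(Nn2c(SCC(=O)Nc3nc(-c4ccc(Cl)cc4)cs3)nc(C)c2C)cc1` arises from compound 1 through (methoxy in place of hydrogen on an aromatic carbon). Going by the values given here, no measured step of this kind is in hand. The change is expected to shift the number by no more than the scatter in either direction, and the step from compound 1 to compound 3 is estimated as a 1.1-fold higher number from compound 1 to compound 3 (0.03 log units; within the scatter). Compound 3 is therefore expected to give about 6000 nM in this assay, with a range from 2500 nM to 15000 nM.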

Compound 3, concentration for 50% growth inhibition: 4060 nM
Estimate against measurement, compound 3: 1.5-fold (0.17 log units) above, and the stated range covers the measured number.
By their numbers in this assay, from the lowest: compounds 3, 1 and 2 (each within the scatter of the next, the first and the last beyond it).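

Going by these compounds alone, this is the first step that differs in one place: in this assay, methoxy in place of hydrogen, para to a large group, gives a 1.4-fold lower number from compound 1 to compound 3 (0.14 log units; within the scatter). The position therefore accepts methoxy with no shift that can be told from the scatter. Nothing at hand bears on the reason for this result.

As far as these compounds go, it remains open whether a dimethylamino group, a carboxylic acid or a longer alkoxy chain at this position would move the number beyond the scatter. From the compounds shown here alone, whether methoxy behaves alike at other carbons of this ring also remains open.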